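Inverting the ring stereocentre of the quinonoid amine

The source may report more compounds than this note shows. Statements on the series, on what has been measured and on what is new or still open speak of the compounds shown alone.

Compound 1 `COc1cc2nc(N3CCC[C@@H](NC(=O)c4ccco4)C3)nc(N)c2cc1OC` gives 110 nM in an assay on CHO cells for displacement of a labelled ligand from Alpha-1A adrenergic receptor (Homo sapiens), with a stated time of 30 min; on this read-out higher numbers stand for weaker inhibition and lower numbers for stronger inhibition. Compound 2 `COc1cc2nc(N3CCC[C@H](NC4=CC(=O)c5ccccc5C4=O)C3)nc(N)c2cc1OC` gives 7.08 nM in this assay and stands lowest of the two numbers measured; its nearest neighbour is compound 1, whose number is much higher, beyond the scatter. Compound 3 `COc1cc2nc(N3CCC[C@@H](NC4=CC(=O)c5ccccc5C4=O)C3)nc(N)c2cc1OC` is unmeasured. Its difference from compound 2: the two compounds have the same atoms and bonds and differ only in configuration as drawn: 1 of 1 stereo elements differ; a stereocentre at a saturated ring carbon is drawn S in compound 2 and R in compound 3. Going by the values given here, no step between measured compounds is available; the opposite configuration is expected to weaken binding, with the step of a 5.6-fold higher number from compound 2 to compound 3 (0.75 log units; beyond the scatter) beyond the scatter. Compound 3 is therefore estimated at 40 nM, in the range 8 nM to 250 nM.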

Compound 3, inhibition constant: 120 nM
Compound 3: the middle estimate sits 3.0-fold (0.48 log units) below what was measured, and the stated range covers the measured number.
By their numbers in this assay, from the lowest: compound 2; then compounds 1 and 3 (each within the scatter of the next).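

In this assay, the stereocentre at the saturated ring carbon now has a measured effect of its own, a 17-fold higher number from compound 2 to compound 3 (1.23 log units; beyond the scatter), which the earlier pair could not separate from the change of group on the amine. With the quinonoid amine in place, the S drawing gives the lower number. The step can be assigned to configuration alone because nothing else changes: the fact that compounds 2 and 3 differ only in the configuration as drawn

Still open, going by these compounds, is whether a step of this size at this ring carbon holds for other groups on the amine, such as an acetyl amide or a carboxylic acid.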